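The compounds below may be only part of what the source reports. "The series", "measured", "known", "first", "only" and "open" are said of these compounds alone.

Within the data shown here, compound 2 `COc1cc2ncnc(Nc3ccc(Cl)cc3)c2cc1OCCCCC(=O)Nc1ccc(S(N)(=O)=O)cc1` gives 31800 nM in a functional assay on NCI-H1975 cells (Homo sapiens) for antiproliferative activity, read by MTT assay, with a stated time of 72 h (a lower number here means a stronger inhibitor, a higher number a weaker inhibitor), the lowest of the two numbers so far. Compound 1 `COc1cc2ncnc(Nc3ccc(F)c(Cl)c3)c2cc1OCCCCC(=O)Nc1ccc(S(N)(=O)=O)cc1` gives 35600 nM in this assay. Among the measured compounds shown here, the one step in hand, a 1.1-fold lower number from compound 1 to compound 2 (0.05 log units; within the scatter), changed the same ring and stayed within the scatter. Compound 3 `COc1cc2ncnc(Nc3ccc(Br)cc3)c2cc1OCCCCC(=O)Nc1ccc(S(N)(=O)=O)cc1` differs from compound 2 by bromo in place of chloro on an aromatic carbon. For the measured compounds named here, no step in hand exchanges one of these two substituents for the other, and the single step on this ring was small, so only a change within the scatter is expected, a 1.1-fold lower number from compound 2 to compound 3 (0.03 log units; within the scatter). Compound 3 is therefore estimated at 30000 nM, within 15000 nM to 60000 nM.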

Compound 3, half-maximal inhibitory concentration: 23300 nM
For compound 3 the middle estimate is 1.3-fold (0.11 log units) above the measured one, within the range that was stated.
By their numbers in this assay, from the lowest: compounds 3, 2 and 1 (each within the scatter of the next).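

In this assay, among these compounds, bromo in place of chloro on this ring, para to a large group, gives a 1.4-fold lower number from compound 2 to compound 3 (0.14 log units; within the scatter), the first exchange of one halogen for another at this place. The wider change, 4-bromophenyl in place of 3-chloro-4-fluorophenyl, gives a 1.5-fold lower number from compound 1 to compound 3 (0.18 log units; within the scatter), so all three halogen patterns now lie within the scatter of one another. No evidence is available to account for these readings.

From the compounds shown here alone, whether an amine or a carboxylic acid in place of the halogen would move the number beyond the scatter remains open. Going by these compounds, the effect of a longer chain in place of the present linker is also open.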